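The source may report more compounds than this note shows. Statements on the series, on what has been measured and on what is new or still open speak of the compounds shown alone.

Measured compounds:
- compound 1 `C[C@H](Nc1nc(N)nc(N)c1C#N)c1cc2ccc(F)cn2c(=O)c1-c1ccccc1`: 1.8 nM
- compound 2 `C[C@H](Nc1nc(N)nc(N)c1C#N)c1cc(=O)n2cc(F)ccc2c1-c1cc(F)cc(F)c1`: 7.02 nM

In a functional assay on OCI-Ly10 cells (Homo sapiens) for inhibition, read by CellTiter-Glo and ATP content, with a stated time of 96 h (a higher number here means a weaker inhibitor, a lower number a stronger inhibitor), compound 1 gives 1.8 nM, the lowest of the two numbers. Among the compounds with values here, compound 2 gives 7.02 nM in this assay, a higher number, and the gap between them lies beyond the usual scatter; the two compounds differ in more than one place, so no single step is recorded between them.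

Compound 3 `C[C@H](Nc1nc(N)nc(N)c1C#N)c1c(-c2ccccc2)c(=O)n2cc(F)ccc2c1-c1ccc(F)cc1` is not yet measured. It differs from compound 1 in one place: 4-fluorophenyl in place of hydrogen on an aromatic carbon. Within the data shown here, no step between measured compounds isolates such a change, so the direction rests only on compound 1 and compound 2 as they stand. Compound 2 carries further aromatic substitution and gives the higher number; on that basis a modest rise beyond the scatter is expected for compound 3, as step a 2.8-fold higher number from compound 1 to compound 3 (0.44 log units; beyond the scatter). The value expected for compound 3 in this assay is 5 nM, within a range from 1.5 nM to 20 nM.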

Compound 3, half-maximal inhibitory concentration in the OCI-Ly10 assay: < 1 nM
Compound 3: no number, only a limit; the forecaster's own chance of this, stated with the estimate: 2%; at least 5.0-fold (0.69 log units) between middle value and limit.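

On the aromatic carbon ortho to a fused ring, 4-fluorophenyl in place of hydrogen gives no loss in the OCI-Ly10 assay, with an at least 1.8-fold lower number from compound 1 to compound 3 (0.25 log units; that floor lies within the scatter). Compound 3 gives < 1 nM there, which is a limit of the assay and not a number. In a physicochemical assay for solubility (a higher number here means a more soluble compound, a lower number a less soluble compound), compound 1 gives 691000 nM and compound 3 gives 68500 nM. In the physicochemical assay the same change comes with a cost in solubility: the measured solubility of compound 1, 691000 nM, and of compound 3, 68500 nM, a 10-fold lower number (1.00 log units; beyond the scatter)

As far as these compounds go, whether a smaller group on this carbon, such as an amine or a carboxylic acid, would hold the number in the OCI-Ly10 assay while giving back solubility remains open. The true distance between compound 1 and compound 3 in the OCI-Ly10 assay also stays open: the floor of that step lies within the scatter, so a real gain in inhibition is not yet shown.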